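Dimethylamino in place of pyrazolyl: compound 4

The source may hold more compounds than are shown below. What is called first, only, known or untested is meant among the compounds shown, and "the series" means these compounds.

For the measured compounds named here, compound 3 `Cc1nn(C)c(-n2cccn2)c1/C=N/OCc1ccc(C(=O)OC(C)(C)C)cc1` gives 5.51 ug/mL in a functional assay on XF498 cells (Homo sapiens) for cytotoxicity (on this read-out lower numbers stand for stronger inhibition and higher numbers for weaker inhibition), the second highest of the three numbers measured so far. Compound 2 `Cc1nn(C)c(-n2ccnc2)c1/C=N/OCc1ccc(C(=O)OC(C)(C)C)cc1` gives 8.15 ug/mL, and a 1.5-fold lower number from compound 2 to compound 3 (0.17 log units; within the scatter). Compound 1 `Cc1nn(C)c(Oc2ccc(Cl)cc2)c1/C=N/OCc1ccc(C(=O)OC(C)(C)C)cc1` gives 0.02 ug/mL; from it, a 410-fold higher number from compound 1 to compound 2 (2.61 log units; beyond the scatter) and a 280-fold higher number from compound 1 to compound 3 (2.44 log units; beyond the scatter). Compound 4 `Cc1nn(C)c(N(C)C)c1/C=N/OCc1ccc(C(=O)OC(C)(C)C)cc1` carries dimethylamino in place of 1H-pyrazol-1-yl on an aromatic carbon. Going by the values given here, no measured step involves dimethylamino. The two large steps show that exchanging 4-chlorophenoxy for a five-membered azole moves the number far up, while the step between the two azoles stays within the scatter. Whether a group with no ring follows the azoles or 4-chlorophenoxy is not shown, so the azole side is taken as the nearer guide. Compound 4 is therefore expected near compound 3, at 5 ug/mL within 1 ug/mL to 25 ug/mL, with the step of a 1.1-fold lower number from compound 3 to compound 4 (0.04 log units; within the scatter) expected to stay within the scatter.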

Compound 4, half-maximal inhibitory concentration: 3.87 ug/mL
Compound 4: the middle estimate sits 1.3-fold (0.11 log units) above what was measured, and the stated range covers the measured number.
By their numbers in this assay, from the lowest: compound 1; then compounds 4, 3 and 2 (each within the scatter of the next, the first and the last beyond it).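

In this assay, dimethylamino, which has no ring, stays close to the two azoles at this aromatic carbon: a 1.4-fold lower number from compound 3 to compound 4 (0.15 log units; within the scatter), and a 2.1-fold lower number from compound 2 to compound 4 (0.32 log units; beyond the scatter). The gap to 4-chlorophenoxy remains large, a 190-fold higher number from compound 1 to compound 4 (2.29 log units; beyond the scatter), so a five-membered aromatic ring at this place is not needed for the high numbers seen with compound 2 and compound 3. No available data bear on the cause of this gap.

The compounds shown do not tell whether the gap follows the ether oxygen, the phenyl ring or the chlorine. Unsubstituted phenoxy and 4-chloroanilino groups at this place would separate these parts.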